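The source may report more compounds than this note shows. Statements on the series, on what has been measured and on what is new or still open speak of the compounds shown alone.

The measured compounds: compound 1 `COc1ccc(/C=C2/C(=O)N(c3ccc(Cl)cc3)N=C2C)cc1OC` gives 2030 nM in an assay for inhibition of Alpha amylase (Homo sapiens), with a stated time of 10 min; a higher number here means a weaker inhibitor, a lower number a stronger inhibitor; compound 2 `COc1cc(/C=C2/C(=O)N(c3ccc(Cl)cc3)N=C2C)cc(OC)c1OC` gives 2190 nM; compound 3 `COc1cc(/C=C2/C(=O)N(c3ccc(Cl)cc3)N=C2C)cc(OC)c1Br` gives 1680 nM.

Compound 4 `COc1ccc(/C=C2/C(=O)N(c3ccc(Cl)cc3)N=C2C)cc1Br` has not been measured. It stands to compound 1 as compound 3 stands to compound 2, with the difference bromo in place of methoxy on an aromatic carbon in one case and bromo in place of methoxy on an aromatic carbon in the other. The two cores themselves differ by hydrogen in place of methoxy on an aromatic carbon. The surroundings are not identical: in compound 2 the place is ortho to two methoxy groups and para to a large group, in compound 1 it is ortho to a methoxy group and meta to a large group, so this is the same kind of change rather than the same change. The measured step was a 1.3-fold lower number from compound 2 to compound 3 (0.12 log units; within the scatter), and a 1.1-fold higher number from compound 1 to compound 2 (0.03 log units; within the scatter) shows the cores are close. He therefore expects a step of about a 1.3-fold lower number from compound 1 to compound 4 (0.10 log units; within the scatter), and for compound 4 an estimated 1600 nM, likely between 800 nM and 3500 nM.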

Compound 4, half-maximal inhibitory concentration: 1920 nM
For compound 4 the middle estimate is 1.2-fold (0.08 log units) below the measured one, within the range that was stated.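

In this assay, bromo in place of methoxy on an aromatic carbon gives a 1.1-fold lower number from compound 1 to compound 4 (0.02 log units; within the scatter). Set beside the same change on the other core, this step does not differ from the earlier one: the same change on two cores in this assay, a 1.3-fold lower number (0.12 log units; within the scatter) from compound 2 to compound 3 and a 1.1-fold lower number (0.02 log units; within the scatter) from compound 1 to compound 4, 1.2-fold (0.09 log units) apart, within the scatter of two such steps. The change thus carries between these two cores without a difference that stands out, but both steps lie within the scatter, so the pair shows neither a real gain nor a real loss from it and says nothing about cores beyond these two.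

The compounds shown leave open whether a different group in this place, such as an amine, a carboxylic acid or a longer chain, would move the number beyond the scatter.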